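This account rests on a few compounds, and the source may have more. Where it says the series, first, only, none or still open, it means among the compounds named here.

Measured in a functional assay on Huh-7 cells (Homo sapiens) for inhibition, read by sulforhodamine B assay, with a stated time of 72 h; a lower number here means a stronger inhibitor, a higher number a weaker inhibitor:
- Compound 1, `COc1ccc(OC)c(C(=O)/C=C/c2cn(-c3ccccc3)nc2-c2ccsc2)c1`: 2100 nM
- Compound 2, `COc1ccc(C(=O)/C=C/c2cn(-c3ccccc3)nc2-c2ccsc2)c(OC)c1`: 3000 nM

On these two numbers compound 1 and compound 2 stand level, since a 1.4-fold higher number from compound 1 to compound 2 (0.15 log units; within the scatter) lies within the scatter of repeated measurements. That step concerns only the group on the carbonyl carbon and leaves the other end of the shared core untouched.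

Compound 3, `COc1ccc(OC)c(C(=O)/C=C/c2cn(-c3ccccc3)nc2-c2cccnc2)c1`, keeps the 2,5-dimethoxyphenyl group of compound 1 and changes the ring at the far end of the core instead: pyridin-3-yl in place of thiophen-3-yl on an aromatic carbon. For the measured compounds named here, no measured step touches this position, so nothing here tells how this assay responds to such a change; the only measured step, a small one on the carbonyl side, cannot stand in for it.

The expectation therefore rests on compound 1 alone: compound 3 is expected to stay close to it, with a 1.2-fold higher number from compound 1 to compound 3 (0.08 log units; within the scatter) and a wide range to reflect the missing evidence. Compound 3 is thus estimated at 2500 nM, between 800 nM and 8000 nM.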

Compound 3, half-maximal inhibitory concentration: 1300 nM
Compound 3: the middle estimate sits 1.9-fold (0.28 log units) above what was measured, within the range that was stated.
By their numbers in this assay, from the lowest: compounds 3, 1 and 2 (each within the scatter of the next, the first and the last beyond it).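

Exchanging thiophen-3-yl for pyridin-3-yl on this aromatic carbon gives a 1.6-fold lower number from compound 1 to compound 3 (0.21 log units; within the scatter) in this assay, so compound 1 and compound 3 stand level. For the compounds shown here, this is the first measured step at this position, and it shows that the five-membered, sulfur-bearing ring is not needed to keep the number in this range: a six-membered aromatic ring with a nitrogen serves as well in this one pair. No measurement of any property of these compounds bears on this result.

On these data alone, both rings are aromatic with one hetero atom, so it remains open how this position would respond to an amine, a carboxylic acid or a longer alkyl chain. Also open, as far as these compounds go, is whether pyridin-3-yl would give a similar number alongside the 2,4-dimethoxyphenyl group of compound 2.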